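Octyloxy to Cyclopentylsulfanyl: Cytotoxicity Outlook for Compound 4

A few compounds are considered here, and "the series" means these few. Any claim that something is new, unique, unknown or untested is made for them only; others in the source may bear on it.

Three measured compounds share one core and differ only in the group on an aromatic carbon of the six-membered aromatic ring with 2 nitrogen. Compound 1 `CCOc1nc(N)nc2c1ncn2/C=C1/CC1(CO)CO` was tested in an ADME assay on Akata cells (Homo sapiens) for cytotoxicity, with a stated time of 7 days (on this read-out higher numbers stand for lower toxicity in this test and lower numbers for higher toxicity in this test), and gave only a limit, > 20000 nM. Compound 2 `COCCOc1nc(N)nc2c1ncn2/C=C1/CC1(CO)CO` likewise returned a limit in this assay, > 20000 nM. Compound 3 `CCCCCCCCOc1nc(N)nc2c1ncn2/C=C1/CC1(CO)CO` also stands at a limit in this assay, > 20000 nM. Compound 3 therefore sits exactly where every measured value sits, at the limit of > 20000 nM in this assay, at which 3 of the 3 values shown sit. None of the steps among these compounds can be sized: a step that the two limits leave unreadable from compound 1 to compound 2, a step that the two limits leave unreadable from compound 1 to compound 3 and a step that the two limits leave unreadable from compound 2 to compound 3 are each hidden by the limits on both sides.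

Compound 4 `Nc1nc(SC2CCCC2)c2ncn(/C=C3/CC3(CO)CO)c2n1` is the next compound, and it differs from compound 3 thus: cyclopentylsulfanyl in place of octyloxy on an aromatic carbon. The three measured steps bear on this change only in that none of them revealed a readable move away from the limit, whatever group occupied this aromatic carbon. For the measured compounds named here, no step in this assay beyond the scatter is therefore expected. The estimated step that the limit leaves unreadable from compound 3 to compound 4 expresses this expectation. Compound 4 is expected to give about 25000 nM in this assay, within 15000 nM to 60000 nM, most probably reported again as a limit.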

Compound 4, half-maximal cytotoxic concentration: > 20000 nM
Compound 4: only a limit was reported; the forecaster's own chance of this, stated with the estimate: 80%; the middle value does not contradict the limit.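

In this assay compound 4 gives > 20000 nM, again a limit. No step from compound 1, compound 2 or compound 3 to compound 4 can be read, because all the values rest at one limit: the limit of > 20000 nM in this assay, at which 4 of the 4 values shown sit.

The compounds shown leave open whether any group on this aromatic carbon brings the read-out to a measurable value, and how far these four compounds truly differ.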